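Halogen swap on an inactive hydrazone-urea

The source may report more compounds than this note shows. Statements on the series, on what has been measured and on what is new or still open speak of the compounds shown alone.

Measured in a functional assay on MCF7 cells (Homo sapiens) for antiproliferative activity, read by MTT assay, with a stated time of 72 h; a lower number here means a stronger inhibitor, a higher number a weaker inhibitor:
- compound 1 `N#Cc1ccc(/C=N/NC(=O)Nc2ccc(Oc3ccnc4[nH]ccc34)c(F)c2)cc1`: "not active" (no number reported)
- compound 2 `O=C(N/N=C/c1cccc([N+](=O)[O-])c1)Nc1ccc(Oc2ccnc3[nH]ccc23)c(F)c1`: "not active" (no number reported)
- compound 3 `O=C(N/N=C/c1ccc(Cl)c(Cl)c1)Nc1ccc(Oc2ccnc3[nH]ccc23)c(F)c1`: 998 nM

Within the data shown here, compound 1 has no single number to its name, and compound 2 is the only other compound in that position. Among the measured compounds shown here, only compound 3 yields a number, so the series offers no measured step to work from.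

Compound 4 `O=C(N/N=C/c1ccc(F)cc1Cl)Nc1ccc(Oc2ccnc3[nH]ccc23)c(F)c1` remains unmeasured. The change leading to it is 2-chloro-4-fluorophenyl in place of 4-cyanophenyl on a carbon with a double bond to nitrogen, with 2-chloro-4-fluorophenyl in place of 4-cyanophenyl on a carbon with a double bond to nitrogen.

The entering group carries chlorine, as does the ring of compound 3, which gives 998 nM. On that thin evidence, a step towards stronger inhibition is expected in this assay, from no number to a measurable one. Its size cannot be stated, as compound 1 provides no number to count from, and another result without a number remains possible.

Compound 4 is expected at about 1500 nM, with an estimated range of 300 nM to 8000 nM.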

Compound 4, half-maximal inhibitory concentration: 7610 nM
The estimate for compound 4 lay 5.1-fold (0.71 log units) below the measured number, and the stated range covers the measured number.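

In this assay, the position on the carbon with a double bond to nitrogen now holds a second ring that gives a number: compound 4, with 2-chloro-4-fluorophenyl, gives 7610 nM, whereas compound 1, with 4-cyanophenyl, gives "not active" (no number reported). Yet the presence of chlorine does not settle the level reached, as replacing 3,4-dichlorophenyl with 2-chloro-4-fluorophenyl gives a 7.6-fold higher number from compound 3 to compound 4 (0.88 log units; beyond the scatter). No measurement on hand accounts for this difference.

The compounds shown leave open whether the placement of the chlorine or the exchange of a chlorine for fluorine separates compound 3 from compound 4, as the two rings differ in both. Going by these compounds, how a 4-chlorophenyl, 4-methoxyphenyl or 4-(dimethylamino)phenyl group would fare at this position also remains open.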